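A few compounds are considered here, and "the series" means these few. Any claim that something is new, unique, unknown or untested is made for them only; others in the source may bear on it.

Series of amides on a shared core, compared in a toxicity assay on THP-1 cells (Homo sapiens) for inhibition; on this read-out higher numbers stand for lower toxicity in this test and lower numbers for higher toxicity in this test. Compound 1 `Cn1c(-c2ccccc2Cl)cnc1NC(=O)c1ccc(F)cc1` sits at the limit of this test: in this assay compound 1 gives > 50000 nM, a limit and not a number. Compound 2 `Cc1ccccc1-c1cnc(NC(=O)c2ccc(F)cc2)n1C` likewise: in this assay compound 2 gives > 50000 nM, again a limit. For the measured compounds named here, compound 3 `Cc1ccc(-c2cnc(NC(=O)c3ccc(F)cc3)n2C)cc1` is the one compound with a number: in this assay compound 3 gives 60000 nM. The steps a step that the two limits leave unreadable from compound 2 to compound 1, a step that the limit leaves unreadable from compound 1 to compound 3 and a step that the limit leaves unreadable from compound 2 to compound 3 are therefore not readable in size, since the limit of > 50000 nM in this assay, at which 2 of the 3 values shown sit, holds two of the three values.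

Compound 4 `Cn1c(-c2ccc(Cl)cc2)cnc1NC(=O)c1ccc(F)cc1` is not yet measured. Going by the values given here, the change from compound 3 to compound 4, (chloro in place of methyl on an aromatic carbon), is the same kind of change as the one from compound 2 to compound 1, (chloro in place of methyl on an aromatic carbon); around the place it is para to a large group in one case and ortho to a large group in the other, so it is the same kind of change, not the same. The earlier step that the two limits leave unreadable from compound 2 to compound 1 gives no readable size. The two cores differ as 4-methylphenyl in place of 2-methylphenyl on an aromatic carbon. The step of a 1.1-fold lower number from compound 3 to compound 4 (0.04 log units; within the scatter) is expected to be small, because compound 3 gives 60000 nM and the other values sit at the limit of > 50000 nM in this assay, at which 2 of the 3 values shown sit. Compound 4 is estimated at 55000 nM, with a range from 30000 nM to 100000 nM.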

Compound 4, half-maximal cytotoxic concentration: 37000 nM
Compound 4: the middle estimate sits 1.5-fold (0.17 log units) above what was measured; the range from low to high includes it.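

In this assay, going from 4-methylphenyl to 4-chlorophenyl gives a 1.6-fold lower number from compound 3 to compound 4 (0.21 log units; within the scatter), so this change on the core of compound 3 cannot be told apart from repeat scatter. The wider comparisons, an at least 1.3-fold lower number from compound 2 to compound 4 (0.13 log units; that floor lies within the scatter) and an at least 1.3-fold lower number from compound 1 to compound 4 (0.13 log units; that floor lies within the scatter), rest on floors and give no firm size or order. Whether the chloro-for-methyl change carries from one core to another remains untested, and the three earlier steps, including the matching step from compound 2 to compound 1, cannot be read because they end at a limit and not a number: the limit of > 50000 nM in this assay, at which 2 of the 4 values shown sit.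

All the compounds shown share the same amide part and the methyl on the shared core, and their aromatic substituents are limited to methyl and chloro. Open, on these data alone, is how this assay responds to an amine or a carboxylic acid on the phenyl ring, or to a longer chain in place of that methyl.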